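A few compounds are considered here, and "the series" means these few. Any claim that something is new, unique, unknown or untested is made for them only; others in the source may bear on it.

Working notes on the series. Compound 1 `COc1cc2c(cc1OC)CN(S(=O)(=O)c1ccc(-n3cc(COc4ccccc4C(C)=O)nn3)cc1)CC2` was tested in a functional assay on HepG2 cells (Homo sapiens) for cytotoxicity, read by MTT assay, with a stated time of 48 h; a lower number here means a stronger inhibitor, a higher number a weaker inhibitor; compound 1 gives > 50 ug/mL, which is a limit of the assay and not a number. Compound 2 `Cc1ccccc1OCc1cn(-c2ccc(S(=O)(=O)N3CCc4ccccc4C3)cc2)nn1` was measured the same way: in this assay compound 2 gives > 50 ug/mL, again a limit rather than a number. Going by the values given here, compound 1 therefore stands at the limit of > 50 ug/mL in this assay, at which 2 of the 2 values shown sit, with no numbered value to anchor it and no measured step in the set. Compound 3 `COc1cc2c(cc1OC)CN(S(=O)(=O)c1ccc(-n3cc(COc4ccc([N+](=O)[O-])cc4)nn3)cc1)CC2` differs from compound 1 in one place: 4-nitrophenyl in place of 2-acetylphenyl on an oxygen on a saturated carbon. Among the compounds with values here, with no measured step to draw on, the expected change from compound 1 to compound 3 in this assay is a step that the limit leaves unreadable from compound 1 to compound 3, that is, nothing beyond the scatter. Compound 3 is accordingly expected to return 60 ug/mL, within 30 ug/mL to 150 ug/mL, most likely reported once more only as a limit.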

Compound 3, half-maximal inhibitory concentration: > 50 ug/mL
Compound 3: no number, only a limit; the forecaster's own chance of this, stated with the estimate: 75%; the middle value lies beyond the limit too.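

Going by these compounds alone, compound 1 and compound 3 both give a limit and not a number, so no step between them can be read in this assay: the limit of > 50 ug/mL in this assay, at which 3 of the 3 values shown sit. The compounds shown leave open whether 2-acetylphenyl and 4-nitrophenyl differ at all in this assay.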